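Benzyl Replaces Aminopyridine on a Core Without Measurable Activity

A few compounds are considered here, and "the series" means these few. Any claim that something is new, unique, unknown or untested is made for them only; others in the source may bear on it.

In an assay on isolated protein for inhibition of Dipeptidyl peptidase 9 (Homo sapiens) (a lower number here means a stronger inhibitor, a higher number a weaker inhibitor), compound 1 `Cc1ccnc(Nc2cc(N3CCNCC3)nc3ccnn23)c1` gives > 100000 nM, which is a limit of the assay rather than a number. Compound 2 `Cc1ccnc(Nc2cc(N3CCC[C@@H](N)C3)nc3ccnn23)c1` carries 3-aminopiperidin-1-yl in place of piperazin-1-yl on an aromatic carbon; in this assay compound 2 gives > 100000 nM, again a limit and not a number. The step that the two limits leave unreadable from compound 1 to compound 2 cannot be read from two limits. Compound 2 thus stands at the limit of > 100000 nM in this assay, at which 2 of the 2 values shown sit, with nothing in the shown data placing it anywhere else.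

Compound 3 `N[C@@H]1CCCN(c2cc(NCc3ccccc3)n3nccc3n2)C1` differs from compound 2 in one place: benzyl in place of 4-methylpyridin-2-yl on a nitrogen on an aromatic ring. No measured step touches this nitrogen, since the one shown step alters the group on an aromatic carbon and is itself unreadable. With only the limit of > 100000 nM in this assay, at which 2 of the 2 values shown sit, to go on, compound 2 has no numerical footing from which a step could be sized, so no step beyond the scatter is expected in this assay in either direction, and the step from compound 2 to compound 3 is estimated as a number no higher from compound 2 to compound 3 (the limit leaves the size open). Compound 3 is expected to give about 100000 nM in this assay, within 20000 nM to 500000 nM, most likely reported again as a limit.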

Compound 3, half-maximal inhibitory concentration: > 100000 nM
Compound 3: a limit, no number; the forecaster's own chance of this, stated with the estimate: 80%; the middle value sits exactly at the limit.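

In this assay compound 3 gives > 100000 nM, again a limit of the assay and not a number. Among the compounds shown here, no step between compound 2 and compound 3 can be read from two limits. The compounds shown leave open how benzyl and 4-methylpyridin-2-yl compare, and whether the shared core can give a measured number in this assay at all: the limit of > 100000 nM in this assay, at which 3 of the 3 values shown sit.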